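The compounds below may be only part of what the source reports. "The series", "measured", "known", "first", "only" and "open" are said of these compounds alone.

Measured so far:
compound 1 `COc1ccc(OC(C)C(=O)Nc2ccc3oc(-c4ccncc4)nc3c2)cc1`: > 5000 nM
compound 2 `C[C@H](Oc1cccc(Cl)c1Cl)C(=O)Nc1ccc2oc(C3=CC=NCC3=O)nc2c1`: > 5000 nM
compound 3 `C[C@H](Oc1cccc(F)c1F)C(=O)Nc1ccc2oc(-c3ccncc3)nc2c1`: > 5000 nM

In an assay on isolated protein for inhibition of GMP reductase 2 (Homo sapiens), read by spectrophotometry (on this read-out higher numbers stand for weaker inhibition and lower numbers for stronger inhibition), compound 1 gives > 5000 nM, which is a limit of the assay and not a number. Compound 3 gives > 5000 nM in this assay, again only a limit. Compound 2 gives > 5000 nM in this assay, likewise a limit and no number. Compound 2 therefore stands nowhere that can be ranked: every value shown sits at the limit of > 5000 nM in this assay, at which 3 of the 3 values shown sit, so none of the three compounds can be told apart from the others on these numbers.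

Compound 4 `C[C@H](Oc1cccc(Cl)c1Cl)C(=O)Nc1ccc2oc(-c3ccc(O)cc3)nc2c1` differs from compound 2 in one place: a group of 7 heavy atoms (6 carbon, 1 oxygen; one six-membered aromatic ring of carbon only) in place of a group of 7 heavy atoms (5 carbon, 1 nitrogen, 1 oxygen; one six-membered non-aromatic ring with 1 hetero atom), on an aromatic carbon. No measured step in this assay joins any two of these compounds, so there is no precedent here for the size of such a change. As far as these compounds go, with compound 2 at a limit, any step that can be seen at all would have to run toward stronger inhibition; a result that stays at the limit is equally open. The expectation for compound 4 in this assay is 3000 nM, with a range from 300 nM to 20000 nM. The step from compound 2 to compound 4 is accordingly estimated as an at least 1.6-fold lower number from compound 2 to compound 4 (0.22 log units; that floor lies within the scatter), with considerable chance that the assay again reports only a limit.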

Compound 4, inhibition constant: > 5000 nM
Compound 4 gave a limit, no number (the forecaster's own chance of this, stated with the estimate: 50%); middle value at least 1.6-fold (0.22 log units) away from the limit.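

In this assay compound 4 gives > 5000 nM, which is a limit and not a number. With compound 2 also at a limit, no step can be read between compound 2 and compound 4: the limit of > 5000 nM in this assay, at which 4 of the 4 values shown sit.

The compounds shown leave open whether any change on the shared core gives a measurable value in this assay.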